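The Same Vinyl Addition, Tried on a Second Core

The compounds below may be only part of what the source reports. "The series", "measured", "known", "first", "only" and "open" are said of these compounds alone.

Compound 1, `CCCCCC[C@@]1(C)SC(=O)C=C1OC`: 14 ug/mL.
Compound 2, `C=CCOC1=CC(=O)S[C@]1(C)CCCCCC`: > 50 ug/mL, a limit of the assay.
Compound 3, `C=CCC1(C)C(=O)S[C@](C)(CCCCCCCC)C1=O`: > 50 ug/mL, a limit of the assay.

All three were tested in a functional assay on MCF7 cells (Homo sapiens) for inhibition; on this read-out higher numbers stand for weaker inhibition and lower numbers for stronger inhibition. Compound 1 gives a numerical value, 14 ug/mL. Compound 2 is reported only as a limit, > 50 ug/mL. The change between them is vinyl in place of hydrogen on a saturated chain carbon bound to an oxygen on an unsaturated carbon, and it produced an at least 3.5-fold higher number from compound 1 to compound 2 (0.55 log units; beyond the scatter), so here the vinyl group went with weaker inhibition.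

Compound 3 is likewise reported only as a limit, > 50 ug/mL. How its core differs from that of compound 1 is not broken down here.

Compound 4, `C=CCC1(CC=C)C(=O)S[C@](C)(CCCCCCCC)C1=O`, has not been measured. It differs from compound 3 by vinyl in place of hydrogen on a saturated chain carbon bound to a saturated ring carbon. Within the data shown here, this is the same kind of change as the one from compound 1 to compound 2, but not the same: there the vinyl entered on a saturated chain carbon bound to an oxygen on an unsaturated carbon, whereas here it enters on a saturated chain carbon bound to a saturated ring carbon.

For compound 4 a value at or beyond the limit is expected, a step that the limit leaves unreadable from compound 3 to compound 4, because compound 3 already sits at the limit of > 50 ug/mL in this assay, at which 2 of the 3 values shown sit, and the earlier vinyl addition gave an at least 3.5-fold higher number from compound 1 to compound 2 (0.55 log units; beyond the scatter). The estimate for compound 4 is therefore 90 ug/mL, most likely reported as a limit, with a plausible range from 40 ug/mL to 250 ug/mL.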

Compound 4, half-maximal inhibitory concentration: > 50 ug/mL
Compound 4 gave a limit, no number; the forecaster's own chance of this, stated with the estimate: 85%; the middle value is on the limit's open side.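

Compound 3 and compound 4 are both reported only as limits, so the size of the step from one to the other cannot be read and the pair adds no new comparison: the limit of > 50 ug/mL in this assay, at which 3 of the 4 values shown sit.

The compounds shown leave open whether vinyl in place of hydrogen at this place on the core of compound 3 weakens inhibition, strengthens it or leaves it unchanged.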